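A few compounds are considered here, and "the series" means these few. Any claim that something is new, unique, unknown or untested is made for them only; others in the source may bear on it.

Compound 1 `Cc1ccc(Nc2ncc(C(F)(F)F)c(N3Cc4cccc(N(C)S(C)(=O)=O)c4C3)n2)cc1C` gives > 30000 nM (a limit)
Compound 2 `CN(c1cccc2c1CN(c1nc(Nc3ccc(Nc4ccccc4)cc3)ncc1C(F)(F)F)C2)S(C)(=O)=O` gives 29800 nM

Among the compounds with values here, in a functional assay on U-87MG ATCC cells for antiproliferative activity against U-87 MG (Homo sapiens), read by spectrophotometry, with a stated time of 2 days (on this read-out higher numbers stand for weaker inhibition of growth and lower numbers for stronger inhibition of growth), compound 2 gives 29800 nM as the only true number so far. Compound 1 gives > 30000 nM as a limit of the assay and not a number. The next compound to be tested is compound 3 `CN(c1cccc2c1CN(c1nc(Nc3ccc(C(F)(F)F)cc3)ncc1C(F)(F)F)C2)S(C)(=O)=O` which keeps the core of compound 2 and carries trifluoromethyl in place of anilino on an aromatic carbon, para to a large group (trifluoromethyl in place of anilino on an aromatic carbon). Within the data shown here, no measured pair yet shows what this change does. Among the measured compounds shown here, with compound 2 at 29800 nM as the only guide in this assay no step beyond the usual scatter is expected, in either direction. The estimated step is small (a 1.0-fold higher number from compound 2 to compound 3 (0.00 log units; within the scatter)). A limit instead of a number would also be no surprise. For compound 3 the estimated value is 30000 nM with an expected range from 10000 nM to 60000 nM in this test.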

Compound 3, concentration for 50% growth inhibition: > 30000 nM
Compound 3: a limit, no number; the forecaster's own chance of this, stated with the estimate: 55%; the middle value lies on the limit itself.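

In this assay compound 3 gives > 30000 nM, which is a limit of the assay and not a number. Putting trifluoromethyl in place of anilino, on an aromatic carbon para to a large group, gives a number no lower from compound 2 to compound 3 (the limit leaves the size open), so removing the anilino ring brings no gain in growth inhibition at this position. The step between the two limits, from compound 1 to compound 3, cannot be read.

From the compounds shown here alone, how much weaker compound 3 may be stays open, because the read-out stops at a ceiling: the limit of > 30000 nM in this assay, at which 2 of the 3 values shown sit. Going by these compounds, whether an amine or a carboxylic acid on this same aromatic carbon would give a number clearly under that ceiling is also open.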